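A few compounds are considered here, and "the series" means these few. Any claim that something is new, unique, unknown or untested is made for them only; others in the source may bear on it.

Measured so far in an ADME assay (liver) for pharmacokinetics, with Liver microsome (Homo sapiens) as the target, using microsomes; a lower number here means that the compound disappears faster, a higher number that the compound lasts longer:

compound 1 `CCOC(=O)/C=C/c1ccc(NC(=O)C2(NC(=O)c3ccc4c(C5CCCC5)c(-c5ncc(Cl)cn5)n(C)c4c3)CCC2)cc1OCC`: > 5 h, a limit of the assay.
compound 2 `CCCOC(=O)/C=C/c1ccc(NC(=O)C2(NC(=O)c3ccc4c(C5CCCC5)c(-c5ncc(Cl)cn5)n(C)c4c3)CCC2)cc1OCC`: > 5 h, a limit of the assay.
compound 3 `CCOc1cc(NC(=O)C2(NC(=O)c3ccc4c(C5CCCC5)c(-c5ncc(Cl)cn5)n(C)c4c3)CCC2)ccc1/C=C/C(=O)OCCOc1ccccc1`: > 5 h, a limit of the assay.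

Compound 2 sits at the limit of this assay, and the same holds for its two neighbours: the limit of > 5 h in this assay, at which 3 of the 3 values shown sit. The step that the two limits leave unreadable from compound 1 to compound 2 and the step that the two limits leave unreadable from compound 2 to compound 3 are therefore unreadable, as is a step that the two limits leave unreadable from compound 1 to compound 3; none of the three shows whether the ester group on this side of the molecule moves the half-life at all.

Compound 4 `CCOc1cc(NC(=O)C2(NC(=O)c3ccc4c(C5CCCC5)c(-c5ncc(Cl)cn5)n(C)c4c3)CCC2)ccc1/C=C/C(=O)OCC(=O)N1CCCC1` differs from compound 2 as follows: (pyrrolidin-1-yl)carbonyl in place of ethyl on a saturated chain carbon bound to an oxygen next to a carbonyl group.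

For the measured compounds named here, no measured step bears on this change in a readable way, so no direction can be taken from the data; the only thing the series shows is that three esters of this kind all reach the limit. On that basis compound 4 is expected to stay near the limit as well, with the step of a number no higher from compound 2 to compound 4 (the limit leaves the size open) from compound 2 estimated as essentially flat. Compound 4 is estimated at 5 h in this assay, in the range 2 h to 10 h.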

Compound 4, half-life: 1.65 h
For compound 4 the middle estimate is 3.0-fold (0.48 log units) above the measured one; the whole stated range lies above it.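

In this assay, for the compounds shown here, compound 4 gives 1.65 h, the first value that is a number and not a limit, so the group on the saturated chain carbon bound to an oxygen next to a carbonyl group can move the half-life. The change reads as (pyrrolidin-1-yl)carbonyl in place of ethyl, an at least 3.0-fold lower number from compound 2 to compound 4 (0.48 log units; beyond the scatter), in place of phenoxymethyl, an at least 3.0-fold lower number from compound 3 to compound 4 (0.48 log units; beyond the scatter), and in place of methyl, an at least 3.0-fold lower number from compound 1 to compound 4 (0.48 log units; beyond the scatter), so it is beyond the scatter against all three esters. The true size of these steps stays open because the other three esters share one limit: the limit of > 5 h in this assay, at which 3 of the 4 values shown sit.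

As far as these compounds go, it remains open whether the lower half-life follows from the amide carbonyl or from the pyrrolidine ring, which a dimethylamide, a piperidine amide or a plain ketone at this place would help to separate. Also open, from the compounds shown here alone, is how the half-life responds when the ester itself gives way to a carboxylic acid or a simple amide, with the rest of the molecule unchanged.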